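Swapping a Benzyl for a Cyclohexylmethyl on a Sulfonamide

A few compounds are considered here, and "the series" means these few. Any claim that something is new, unique, unknown or untested is made for them only; others in the source may bear on it.

Among the measured compounds shown here, compound 2 `CCOC(=O)c1oc2ccc(N(Cc3ccccc3)S(=O)(=O)c3ccc(Cl)cc3)cc2c1C` is the one compound here with a measured number: in a functional assay on HCT-116 cells (Homo sapiens) for inhibition, read by MTT assay, with a stated time of 72 h (a lower number here means a stronger inhibitor, a higher number a weaker inhibitor), compound 2 gives 4860 nM. Compound 1 `CCOC(=O)c1oc2ccc(N(Cc3ccccc3)S(=O)(=O)c3ccc([N+](=O)[O-])cc3)cc2c1C` carries a nitro group in place of that chloro. In this assay compound 1 gives only a limit, > 40000 nM. For the measured compounds named here, the step of an at least 8.2-fold lower number from compound 1 to compound 2 (0.91 log units; beyond the scatter) is the only measured step, and because it rests on the limit of > 40000 nM in this assay, at which 1 of the 2 values shown sits, its size is known only as a floor. Compound 3 `CCOC(=O)c1oc2ccc(N(CC3CCCCC3)S(=O)(=O)c3ccc(Cl)cc3)cc2c1C` differs from compound 2 in a different part of the molecule: cyclohexyl in place of phenyl on a saturated chain carbon bound to a sulfonamide nitrogen. Going by the values given here, no measured step touches that part, so the swap from nitro to chloro gives no guide to it. The expected step of a 1.0-fold higher number from compound 2 to compound 3 (0.00 log units; within the scatter) is therefore within the scatter, in no particular direction. Compound 3 is expected to give about 4900 nM in this assay, with a range from 1500 nM to 16000 nM.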

Compound 3, half-maximal inhibitory concentration: 14100 nM
Compound 3: the middle estimate sits 2.9-fold (0.46 log units) below what was measured; the range from low to high includes it.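

Replacing benzyl with cyclohexylmethyl on the sulfonamide nitrogen gives, in this assay, a 2.9-fold higher number from compound 2 to compound 3 (0.46 log units; beyond the scatter), which shows that this part of the molecule, untouched by the earlier step, does influence the read-out. The two groups have the same count of carbon atoms and neither has a hydrogen-bond donor or acceptor, so within this one pair the aromatic ring goes with the lower number, though a single pair sets no general rule. Nothing measured here explains why the number moves.

Still open, on these data alone, is how a ring containing nitrogen, such as pyridinylmethyl, or an open chain, such as hexyl, would behave on the sulfonamide nitrogen. As far as these compounds go, it is also open whether the same swap would give a similar step with a carboxylic acid in place of the ethyl ester.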